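This account rests on a few compounds, and the source may have more. Where it says the series, first, only, none or still open, it means among the compounds named here.

Series of compound 1, `COc1ccc(NC(=O)NCCNS(=O)(=O)c2ccc(-c3ccccc3Oc3ccc([N+](=O)[O-])cc3)s2)cc1`, with a shared core and an amide-linked tail. In an ADME assay on HEK-293T cells (Homo sapiens) for cytotoxicity, read by CCK-8 assay, with a stated time of 48 h (a lower number here means a stronger inhibitor, a higher number a weaker inhibitor), compound 1 sits only at a limit, > 20000 nM. Compound 2, `O=[N+]([O-])c1ccc(Oc2ccccc2-c2ccc(S(=O)(=O)NCCNC(=S)Nc3cccc(Cl)c3)s2)cc1`, is the one measured partner: in this assay compound 2 gives 4990 nM. For the measured compounds named here, that gives the single measured step, an at least 4.0-fold lower number from compound 1 to compound 2 (0.60 log units; beyond the scatter), which is bounded on one side by the limit, (the limit of > 20000 nM in this assay, at which 1 of the 2 values shown sits). The step to compound 2 changes the tail on the amine nitrogen, not the ether side of the core.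

Compound 3, `COc1ccc(NC(=O)NCCNS(=O)(=O)c2ccc(-c3ccccc3OCc3cccc(O)c3)s2)cc1`, takes the other route. It differs from compound 1 by 3-hydroxybenzyl in place of 4-nitrophenyl on an oxygen on an aromatic ring. No measured step touches this position, so nothing shown bears on its size or direction; the step to compound 2 is at a different place and cannot be carried over. With compound 1 standing only at a limit, the working expectation for compound 3 is a step of no clear size, a number no higher from compound 1 to compound 3 (the limit leaves the size open), and a fair chance that the read-out again stops at a limit. Compound 3 is therefore estimated at 20000 nM, between 5000 nM and 60000 nM.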

Compound 3, half-maximal inhibitory concentration: > 20000 nM
Compound 3: only a limit was reported (the forecaster's own chance of this, stated with the estimate: 65%); the middle value sits exactly at the limit.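

In this assay compound 3 gives > 20000 nM, a limit and not a number, and compound 1 also stands at a limit, so no step can be read between compound 1 and compound 3: the limit of > 20000 nM in this assay, at which 2 of the 3 values shown sit.

The compounds shown leave open how far 3-hydroxybenzyl in place of 4-nitrophenyl on an oxygen on an aromatic ring moves the read-out, or in which direction.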